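A few compounds are considered here, and "the series" means these few. Any claim that something is new, unique, unknown or untested is made for them only; others in the source may bear on it.

Measured compounds:
compound 1 `Fc1ccc(C2=CC3CNCC(C2)C3)cn1` with 0.4 nM
compound 2 `COc1ccccc1Oc1cncc(C2=CC3CNCC(C2)C3)c1` with 1 nM
compound 3 `C1=C(c2cccnc2)C[C@@H]2CNC[C@H]1C2` with 0.1 nM

All three were run in an in vitro assay on SH-EP1 cells for displacement of a labelled ligand from Neuronal acetylcholine receptor; alpha4/beta2 (Homo sapiens); a higher number here means a weaker inhibitor, a lower number a stronger inhibitor. Compound 2 has the highest number of the three. The nearest to it is compound 1, whose value of 0.4 nM is lower by a margin beyond the scatter, and the furthest is compound 3, which gives 0.1 nM in this assay, again a gap beyond the scatter. Compound 2 thus reads as the weakest of this small set, while compound 1 and compound 3 both sit well below it.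

The next compound, compound 4 `CC(C)Oc1cncc(C2=CC3CNCC(C2)C3)c1`, has not yet been measured. It differs from compound 2 in one place: isopropyl in place of 2-methoxyphenyl on an oxygen on an aromatic ring. Among the measured compounds shown here, no pair of measured compounds shows this exact change, so its effect can only be reasoned from the three numbers in hand. Those numbers show that the shared core itself, with little on it, reaches very low values, and that compound 2 with its larger attachment sits highest. A smaller group in that place would therefore be expected to leave the number unchanged or to lower it modestly, not to raise it. For compound 4 the expected step is a 1.7-fold lower number from compound 2 to compound 4 (0.22 log units; within the scatter). Compound 4 is estimated at 0.6 nM, within a range from 0.2 nM to 2 nM.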

Compound 4, inhibition constant: 0.26 nM
Compound 4: the middle estimate sits 2.3-fold (0.36 log units) above what was measured; measured number inside the range.
By their numbers in this assay, from the lowest: compound 3; then compounds 4 and 1 (each within the scatter of the next); then compound 2.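

Putting isopropyl in place of 2-methoxyphenyl on an oxygen on an aromatic ring gives, in this assay, a 3.8-fold lower number from compound 2 to compound 4 (0.59 log units; beyond the scatter) and so provides a direct reading of a change at this position. The earlier compounds shown here differ from one another in more than one place, so they could only suggest how the large attachment of compound 2 relates to its number, whereas this pair isolates the change. It shows that the 2-methoxyphenyl group, with its six-membered aromatic ring, is not needed for a sub-nanomolar-range reading here, since the ringless isopropyl gives a lower number by a margin beyond the scatter, though nothing at hand bears on why.

This single pair cannot separate the loss of the aromatic ring from the loss of the methoxy oxygen or from the drop in heavy atoms. As far as these compounds go, how a methyl, a cyclopropyl or an unsubstituted phenyl on the same oxygen would read remains open, as does the effect of an amine in place of that oxygen.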